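The source may hold more compounds than are shown below. What is called first, only, known or untested is meant among the compounds shown, and "the series" means these compounds.

All four compounds share one core, a five-membered non-aromatic ring with two nitrogens that carries a 4-(dimethylamino)phenyl group and a second aryl group, and differ in what sits on the ring nitrogen and in the second aryl group. Compound 1 `Cc1ccc(S(=O)(=O)N2N=C(c3ccc(N4CCN(C)CC4)cc3)CC2c2ccc(N(C)C)cc2)cc1` bears a (4-methylphenyl)sulfonyl group on the ring nitrogen and a methylpiperazinyl-substituted phenyl ring; in a functional assay on MDA-MB-231 cells (Homo sapiens) for inhibition, read by sulforhodamine B assay, tested at 10 uM (a higher number here means more inhibition at the concentration tested (going by the name of the read-out), a lower number less inhibition), compound 1 gives 10.7%. Compound 2 `C=C(C)C(=O)N1N=C(c2ccc(-n3ccnc3)cc2)CC1c1ccc(N(C)C)cc1` carries a 1-methylethenyl-carbonyl group and an imidazolyl-substituted phenyl ring; in this assay compound 2 gives 4.3%. Among the measured compounds shown here, compound 3 `COC(=O)CC(=O)N1N=C(c2ccc(-n3ccnc3)cc2)CC1c1ccc(N(C)C)cc1` gives 2.3%, the lowest of the three numbers, but the only measured step is a number 2 percentage points lower from compound 2 to compound 3 (within the scatter), and the gap to compound 1 is also within the scatter, so the three numbers cannot be told apart.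

Compound 4 `Cc1ccc(S(=O)(=O)N2N=C(c3ccc(-n4ccnc4)cc3)CC2c2ccc(N(C)C)cc2)cc1` differs from compound 3 in one place: (4-methylphenyl)sulfonyl in place of ((methoxycarbonyl)methyl)carbonyl on an amine nitrogen in a ring. For the measured compounds named here, no measured step swaps an acyl group for a sulfonyl group, so the only guide is the measured one, a number 2 percentage points lower from compound 2 to compound 3 (within the scatter), which changed little, together with the fact that compound 1, which already carries the (4-methylphenyl)sulfonyl group, gives 10.7%. The step is therefore expected to be a number 5.7 percentage points higher from compound 3 to compound 4 (within the scatter), not beyond the scatter. Compound 4 is expected to give 8%, between -2% and 20%.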

Compound 4, a percentage reported as inhibition, at one concentration (the size of the read-out at that concentration, not a potency): 50.8%
For compound 4 the middle estimate is 42.8 percentage points below the measured one; measured number above the stated range.
By their numbers in this assay, from the lowest: compounds 3, 2 and 1 (each within the scatter of the next); then compound 4.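

In this assay, the group on the amine nitrogen in a ring of the shared core can strongly change the result. Placing (4-methylphenyl)sulfonyl there instead of an acyl group gives a number 48.5 percentage points higher from compound 3 to compound 4 (beyond the scatter) and a number 46.5 percentage points higher from compound 2 to compound 4 (beyond the scatter), whereas exchanging one acyl group for the other had stayed within the scatter. The sulfonyl group does not produce this result alone, as compound 1 carries it too, yet 1H-imidazol-1-yl in place of 4-methylpiperazin-1-yl on an aromatic carbon gives a number 40.1 percentage points higher from compound 1 to compound 4 (beyond the scatter), so among these compounds the high number appears only where the two groups occur together, in compound 4; no available evidence explains this combined effect.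

On these data alone, it remains open whether the methyl on the phenyl ring of the sulfonyl group matters, or whether a smaller methylsulfonyl group or another aryl sulfonyl group would give a similar result. It is also unknown whether a pyridine or a morpholine ring could take the place of the imidazole, and how compound 4 would behave across a range of concentrations.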